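The source may report more compounds than this note shows. Statements on the series, on what has been measured and on what is new or still open speak of the compounds shown alone.

In a functional assay on BGC-823 cells (Homo sapiens) for antiproliferative activity, read by MTT assay, with a stated time of 48 h (on this read-out lower numbers stand for stronger inhibition and higher numbers for weaker inhibition), compound 2 (`S=c1oc(-c2ccc3c(c2)OCCO3)nn1CN1CCN(c2ccccc2)CC1`) gives > 50000 nM as its reading, which is a limit of the assay and not a number. In this assay compound 1 (`Cc1ccc(N2CCN(Cn3nc(-c4ccc5c(c4)OCCO5)oc3=S)CC2)c(C)c1`) gives 28300 nM as a measured reading. The next analogue is compound 3 (`O=[N+]([O-])c1ccc(N2CCN(Cn3nc(-c4ccc5c(c4)OCCO5)oc3=S)CC2)cc1`), with nitro in place of hydrogen on an aromatic carbon, that is, phenyl to 4-nitrophenyl. Going by the values given here, the only measured step that bears on this change is an at least 1.7-fold higher number from compound 1 to compound 2 (0.24 log units; that floor lies within the scatter) as the comparison at the same amine nitrogen. It gives a floor and no exact size, so it is a weak guide. A modest shift to a lower number is therefore expected in this assay, and compound 3 may also reach the assay limit. The working expectation is an at least 1.4-fold lower number from compound 2 to compound 3 (0.15 log units; that floor lies within the scatter) as the estimated step. Compound 3 is estimated at 35000 nM with an expected range from 12000 nM to 90000 nM as the working figure.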

Compound 3, half-maximal inhibitory concentration: > 50000 nM
Compound 3 was reported as a limit (the forecaster's own chance of this, stated with the estimate: 40%); middle value at least 1.4-fold (0.15 log units) away from the limit.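

In this assay compound 3 gives > 50000 nM, which is a limit of the assay and not a number. The step from 2,4-dimethylphenyl to 4-nitrophenyl on the amine nitrogen in the ring gives only a floor, an at least 1.7-fold higher number from compound 1 to compound 3 (0.24 log units; that floor lies within the scatter), so these two groups cannot be ranked. The effect of nitro in place of hydrogen on the aromatic carbon cannot be read, since both readings around that change are limits: the limit of > 50000 nM in this assay, at which 2 of the 3 values shown sit.

As far as these compounds go, the size of any effect of nitro at this place on the ring stays open, as does whether either methyl group of compound 1 alone is enough to give a measured reading. An amine or a methoxy group on the same aromatic carbon would test whether this place can give a reading below the limit.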